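The source may report more compounds than this note shows. Statements on the series, on what has been measured and on what is new or still open speak of the compounds shown alone.

Series notes, three compounds sharing one core, each carrying a furanyl group and a methyl on that core and differing only in the group on the carbonyl carbon. In an assay on membranes from HeLa cells for displacement of a labelled ligand from adenosine receptor A3 (Homo sapiens), read by scintillation counting, with a stated time of 180 min, tested at 1 uM (on this read-out lower numbers stand for less inhibition and higher numbers for more inhibition at the one concentration tested (going by the name of the read-out)), compound 1 `CCCOC(=O)C1=C(C)NC(=O)NC1c1ccoc1` gives 11%, compound 2 `CC1=C(C(=O)OCC(C)C)C(c2ccoc2)NC(=O)N1` gives 16%, and compound 3 `CC1=C(C(=O)CC(C)C)C(c2ccoc2)NC(=O)N1` gives 18%. Within the data shown here, compound 3 thus carries the largest of the three numbers, but the spread is narrow: a number 7 percentage points higher from compound 1 to compound 3 (within the scatter) and a number 2 percentage points higher from compound 2 to compound 3 (within the scatter), and also a number 5 percentage points higher from compound 1 to compound 2 (within the scatter), so no pair is separated beyond the scatter and no ordering of the three can be read from them.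

Compound 4 `CCC(C)OC(=O)C1=C(C)NC(=O)NC1c1ccoc1` is not yet measured in this assay. It differs from compound 3 by sec-butoxy in place of isobutyl on a carbonyl carbon. Two measured steps speak to a swap at this same carbonyl carbon: the propoxy-to-isobutyl change in a number 7 percentage points higher from compound 1 to compound 3 (within the scatter) and the isobutoxy-to-isobutyl change in a number 2 percentage points higher from compound 2 to compound 3 (within the scatter), both within the scatter. Returning from isobutyl to an alkoxy group, here sec-butoxy, is therefore expected to move this assay by no more than the scatter, and if anything toward the values of compound 1 and compound 2. The expected step is a number 5 percentage points lower from compound 3 to compound 4 (within the scatter). For compound 4 the estimate in this assay is 13%, with a range from 4% to 22%.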

Compound 4, a percentage reported as inhibition, at one concentration (the size of the read-out at that concentration, not a potency): 11%
Estimate against measurement, compound 4: 2 percentage points above; low and high end bracket the measured number.
By their numbers in this assay, from the lowest: compounds 1, 4, 2 and 3 (each within the scatter of the next).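

In this assay, sec-butoxy on the carbonyl carbon adds a third alkoxy group to the comparison, and it separates from neither isobutyl nor the other alkoxy groups: a number 7 percentage points lower from compound 3 to compound 4 (within the scatter), a number 5 percentage points lower from compound 2 to compound 4 (within the scatter) and no change at the digits printed from compound 1 to compound 4 (within the scatter). The last two steps are new in kind, as they alter the chain on the oxygen at a saturated chain carbon bound to that oxygen, whereas the earlier methyl step sat on a saturated chain carbon bound to two saturated chain carbons, and neither placement of the added methyl gives a difference beyond the scatter. All four groups at this position therefore remain within the scatter of one another, and no measurement at hand bears on why the numbers lie so close.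

On these data alone, whether any group on this carbonyl carbon can move the number beyond the scatter remains open, for example an amine, a carboxylic acid or a longer chain in place of sec-butoxy. Also open, as far as these compounds go, is how the compounds would rank in potency, as a percentage at one concentration gives no potency.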